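A few compounds are considered here, and "the series" means these few. Any claim that something is new, unique, unknown or untested is made for them only; others in the source may bear on it.

Two compounds have been measured so far in a functional assay on HT-29 cells (Homo sapiens) for antiproliferative activity, read by sulforhodamine B assay, with a stated time of 48 h; a lower number here means a stronger inhibitor, a higher number a weaker inhibitor:

compound 1 `O=C1NCCN1c1ccc(S(=O)(=O)Nc2ccc(OC(F)F)cc2)cc1`: 650 nM
compound 2 `CCCCOc1ccc(NS(=O)(=O)c2ccc(N3CCNC3=O)cc2)cc1`: 630 nM

Compound 2, at 630 nM, lies within the scatter of compound 1, so neither can be ranked over the other. Compound 3 `CCCCCCOc1ccc(NS(=O)(=O)c2ccc(N3CCNC3=O)cc2)cc1` has not yet been measured. It differs from compound 2 by a single change, (ethyl in place of hydrogen on a saturated chain carbon, four bonds along the chain from an oxygen on an aromatic ring), that is, ethyl in place of hydrogen on a saturated chain carbon, four bonds along the chain from an oxygen on an aromatic ring. For the measured compounds named here, only one measured step bears on this, and only loosely: a 1.0-fold lower number from compound 1 to compound 2 (0.01 log units; within the scatter), with butyl in place of difluoromethyl on an oxygen on an aromatic ring. That step lies within the scatter, and it alters the same group on that oxygen without being the same change. Two compounds show no trend with chain size, so no direction is favoured, and no step beyond the scatter is expected in this assay. The expected step is a 1.0-fold higher number from compound 2 to compound 3 (0.01 log units; within the scatter). For compound 3 the estimated value is 650 nM, with an expected range from 230 nM to 1800 nM.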

Compound 3, half-maximal inhibitory concentration: > 1000 nM
Compound 3: only a limit was reported; the forecaster's own chance of this, stated with the estimate: 5%; middle value at least 1.5-fold (0.18 log units) from the limit.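

Compound 3 gives > 1000 nM in this assay, and this figure is a limit of the assay, not a number. Where the earlier change on this oxygen gave two measured values within the scatter of each other, ethyl in place of hydrogen on this saturated chain carbon gives a step with a direction but only a floor for its size, an at least 1.5-fold higher number from compound 2 to compound 3 (0.20 log units; that floor lies within the scatter), and the comparison of hexyl with difluoromethyl on the same oxygen reads an at least 1.5-fold higher number from compound 1 to compound 3 (0.18 log units; that floor lies within the scatter). Both floors lie within the scatter, so the data do not yet separate compound 3 from compound 1 or compound 2, and the true size of each step cannot be read because compound 3 sits at a limit: the limit of > 1000 nM in this assay, at which 1 of the 3 values shown sits.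

The compounds shown leave open how a pentyl group or a longer chain on this oxygen would read in this assay. They also leave open whether an amine or a carboxylic acid carried on the hexyl chain would return a measured value rather than a limit.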